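The source may hold more compounds than are shown below. What is called first, only, known or untested is meant among the compounds shown, and "the series" means these compounds.

In an ADME assay on NIH3T3 cells (Mus musculus) for cytotoxicity, read by MTT assay, with a stated time of 24 h (on this read-out higher numbers stand for weaker inhibition and lower numbers for stronger inhibition), compound 2 `COc1cccc(/C=N/NC(=O)CSc2nnc(-c3ccncc3)o2)c1` gives 179000 nM. Among the measured compounds shown here, the only other number in this assay comes from compound 1 `O=C(CSc1nnc(-c2ccncc2)o1)N/N=C/c1ccccc1`, which gives 167000 nM. The step of a 1.1-fold higher number from compound 1 to compound 2 (0.03 log units; within the scatter) shows that compound 2 stands alongside compound 1, with neither value set apart from the other, so compound 2 cannot be called weaker or stronger than compound 1 on what has been measured.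

Compound 3 `O=C(CSc1nnc(-c2ccncc2)o1)N/N=C/c1ccccc1O` has not yet been measured in this assay. It differs from compound 2 by 2-hydroxyphenyl in place of 3-methoxyphenyl on a carbon with a double bond to nitrogen. For the measured compounds named here, no measured step matches this exact exchange; the one step at hand, a 1.1-fold higher number from compound 1 to compound 2 (0.03 log units; within the scatter), is itself a change to that aromatic ring and did not move the number beyond the scatter. Going by the values given here, only one such step is known, so the expectation rests on thin ground. On that basis the step of a 1.1-fold lower number from compound 2 to compound 3 (0.02 log units; within the scatter) is estimated to stay within the scatter, with no clear direction. Compound 3 is expected to give 170000 nM in this assay, with a likely range from 80000 nM to 360000 nM.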

Compound 3, half-maximal inhibitory concentration: 155000 nM
Compound 3: the middle estimate sits 1.1-fold (0.04 log units) above what was measured; the measured number falls inside the stated range.
By their numbers in this assay, from the lowest: compounds 3, 1 and 2 (each within the scatter of the next).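

In this assay, the step of a 1.2-fold lower number from compound 2 to compound 3 (0.06 log units; within the scatter) comes from putting 2-hydroxyphenyl in place of 3-methoxyphenyl on a carbon with a double bond to nitrogen, and the step of a 1.1-fold lower number from compound 1 to compound 3 (0.03 log units; within the scatter) comes from adding a hydroxy group to the aromatic ring. These steps add a second kind of substituent on this aromatic ring, and the entering 2-hydroxyphenyl carries a hydrogen-bond donor that 3-methoxyphenyl does not, yet neither step separates the numbers, so all three compounds remain indistinguishable in this read-out. Nothing available on these compounds bears on this result.

The compounds shown leave open whether an amine or a carboxylic acid on this aromatic ring would give a number set apart from these three, as hydroxy and methoxy are the only substituents shown there. They also leave open what a longer chain in place of the link between the carbonyl and the sulfur would do, as all three compounds share the rest of the core unchanged.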